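A few compounds are considered here, and "the series" means these few. Any claim that something is new, unique, unknown or untested is made for them only; others in the source may bear on it.

The measured compounds:
compound 1 `Cc1ccc(NC(=O)COc2ccc3cc(/C=C4/SC(=O)NC4=O)ccc3c2)cc1`: 1700 nM
compound 2 `O=C(COc1ccc2cc(/C=C3/SC(=O)NC3=O)ccc2c1)Nc1ccc(F)cc1F`: 3900 nM
compound 3 `O=C(COc1ccc2cc(/C=C3/SC(=O)NC3=O)ccc2c1)Nc1cccc(C(F)(F)F)c1`: 2500 nM

In an assay on isolated protein for inhibition of histone deacetylase 4 (Homo sapiens), with a stated time of 1 h (on this read-out higher numbers stand for weaker inhibition and lower numbers for stronger inhibition), compound 1 gives the lowest of the three numbers; compound 3 sits close to it, and compound 2 stands furthest off. Compound 4 `O=C(COc1ccc2cc(/C=C3/SC(=O)NC3=O)ccc2c1)Nc1ccc(Cl)c(Cl)c1` differs from compound 1 by 3,4-dichlorophenyl in place of 4-methylphenyl on an amide-type nitrogen. For the measured compounds named here, two measured steps bear on this change, both swaps of the aryl group on the same amide-type nitrogen: a 2.3-fold higher number from compound 1 to compound 2 (0.36 log units; beyond the scatter) and a 1.5-fold higher number from compound 1 to compound 3 (0.17 log units; within the scatter). Neither moved the number far, and the one that reached beyond the scatter did so only modestly, toward a higher number. The account therefore expects compound 4 to land near compound 1 or a little higher. The step expected is a 1.5-fold higher number from compound 1 to compound 4 (0.17 log units; within the scatter). Compound 4 is estimated at 2500 nM, in a range from 1000 nM to 6000 nM.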

Compound 4, half-maximal inhibitory concentration: 5500 nM
Beside the measured number, compound 4's estimate is 2.2-fold (0.34 log units) below it; the measured number falls inside the stated range.
By their numbers in this assay, from the lowest: compounds 1, 3, 2 and 4 (each within the scatter of the next, the first and the last beyond it).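

In this assay, placing 3,4-dichlorophenyl on the amide-type nitrogen gives the first step from compound 1 that is clearly larger than modest scatter alone would suggest (a 3.2-fold higher number from compound 1 to compound 4 (0.51 log units; beyond the scatter)). The change also separates two aryl groups at this position (a 2.2-fold higher number from compound 3 to compound 4 (0.34 log units; beyond the scatter)), while 3,4-dichlorophenyl and 2,4-difluorophenyl remain within the scatter of each other (a 1.4-fold higher number from compound 2 to compound 4 (0.15 log units; within the scatter)). No available evidence explains these differences.

Every group shown here on this nitrogen is a substituted phenyl ring. As far as these compounds go, how a pyridine ring, a carboxylic acid on the ring or an aminoalkyl chain would read remains open.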